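Moving the thiophene link on an inactive compound

The source may report more compounds than this note shows. Statements on the series, on what has been measured and on what is new or still open speak of the compounds shown alone.

In a functional assay on A549 cells (Homo sapiens), read by MTT assay, with a stated time of 72 h (on this read-out lower numbers stand for stronger inhibition and higher numbers for weaker inhibition), compound 1 (`COc1ncnc2c1c(-c1cc3ccccc3o1)cn2[C@@H]1O[C@H](CO)[C@@H](O)[C@H]1O`) gives 17700 nM, and compound 2 (`CSc1ncnc2c1c(-c1ccoc1)cn2[C@@H]1O[C@H](CO)[C@@H](O)[C@H]1O`) gives 280 nM. Compound 3 (`CSc1ncnc2c1c(-c1cccs1)cn2[C@@H]1O[C@H](CO)[C@@H](O)[C@H]1O`) reads > 20000 nM, which is a limit of the assay and not a number. Its true position on the scale is therefore unknown.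

Compound 4 (`CSc1ncnc2c1c(-c1ccsc1)cn2[C@@H]1O[C@H](CO)[C@@H](O)[C@H]1O`) has the same atoms as compound 3, joined differently: thiophen-3-yl in place of thiophen-2-yl on an aromatic carbon. Thiophen-3-yl replaces thiophen-2-yl on an aromatic carbon, so compound 4 keeps the thiophene of compound 3 but carries it through the 3-yl link seen in the furan-3-yl of compound 2.

Among the compounds with values here, only one measured step bears on this change, and it is large: an at least 71-fold higher number from compound 2 to compound 3 (1.85 log units; beyond the scatter). That step changes both the ring and the link, so it cannot show how much the link alone contributes. Part of that loss may return, but this is an expectation with wide uncertainty.

In this assay, the expected step toward stronger inhibition is an at least 13-fold lower number from compound 3 to compound 4 (1.12 log units; beyond the scatter). Compound 4 is estimated at 1500 nM, with an expected range from 200 nM to 20000 nM.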

Compound 4, half-maximal inhibitory concentration: > 20000 nM
Compound 4: a limit, no number; the forecaster's own chance of this, stated with the estimate: 25%; at least 13-fold (1.12 log units) between middle value and limit.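

Carrying the thiophene through the 3-yl link does not restore what compound 2 shows. In this assay the change of thiophen-3-yl for furan-3-yl alone gives an at least 71-fold higher number from compound 2 to compound 4 (1.85 log units; beyond the scatter). Compound 3 could not show this, since its step from compound 2 changed both ring and link, whereas here the link stays the same and only the ring differs; the step between compound 3 and compound 4 cannot be read, as both values are limits: the limit of > 20000 nM in this assay, at which 2 of the 4 values shown sit.

From the compounds shown here alone, how the two thiophene compounds rank against each other therefore remains open. Also open, going by these compounds, is whether furan-2-yl on the same aromatic carbon would stay close to compound 2, which would show whether the link matters when the ring is furan.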